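Amide aryl variation on the shared core: pyridine to phenyl

The compounds below may be only part of what the source reports. "The series", "measured", "known", "first", "only" and "open" are said of these compounds alone.

Three amides on a shared core have been measured in an assay on CHO cells for positive allosteric modulation of metabotropic glutamate receptor 5 (Homo sapiens), read by FLIPR; on this read-out lower numbers stand for an effect already at smaller amounts and higher numbers for an effect only at larger amounts of compound. Compound 1 `COc1cccc(C(=O)Nc2ccc(Cl)cc2CN2C(=O)c3ccccc3C2=O)c1` gives 1500 nM in this assay. Compound 2 `O=C(Nc1ccc(Cl)cc1CN1C(=O)c2ccccc2C1=O)c1ccccc1[N+](=O)[O-]` gives 5700 nM. Compound 3 `O=C(Nc1ccc(Cl)cc1CN1C(=O)c2ccccc2C1=O)c1cccnc1` gives 35000 nM, the highest number of the three; the steps of a 23-fold higher number from compound 1 to compound 3 (1.37 log units; beyond the scatter) and a 6.1-fold higher number from compound 2 to compound 3 (0.79 log units; beyond the scatter) both lie beyond the scatter, so compound 3 is the weakest of the measured set on this read-out.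

Compound 4 `O=C(Nc1ccc(Cl)cc1CN1C(=O)c2ccccc2C1=O)c1ccccc1` has not been measured in this assay. It differs from compound 3 in one place: phenyl in place of pyridin-3-yl on a carbonyl carbon.

Within the data shown here, two measured steps bear on this change, since both replace the pyridin-3-yl of compound 3 with a substituted phenyl on the same carbonyl carbon: read in reverse, a 23-fold higher number from compound 1 to compound 3 (1.37 log units; beyond the scatter) and a 6.1-fold higher number from compound 2 to compound 3 (0.79 log units; beyond the scatter). Both run in the same direction, from compound 3 towards lower numbers, one large and one modest. An unsubstituted phenyl carries neither the methoxy of compound 1 nor the nitro of compound 2, so a step of intermediate size is expected, with a lower number for compound 4 than for compound 3, well beyond the scatter: a 7.0-fold lower number from compound 3 to compound 4 (0.85 log units; beyond the scatter) is the expected change. Compound 4 is therefore estimated at 5000 nM in this assay, within a range from 1500 nM to 17000 nM.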

Compound 4, half-maximal effective concentration: > 100000 nM
Compound 4 was reported as a limit (the forecaster's own chance of this, stated with the estimate: 10%); middle value at least 20-fold (1.30 log units) away from the limit.
By their numbers in this assay, from the lowest: compound 1; then compound 2; then compound 3. At a limit, above all of these: compound 4.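

In this assay compound 4 gives > 100000 nM, which is a limit of the assay and not a number. Unsubstituted phenyl therefore does not act as a parent ring that methoxy or nitro merely adjusts: the change from pyridin-3-yl gives an at least 2.8-fold higher number from compound 3 to compound 4 (0.45 log units; beyond the scatter), hydrogen in place of nitro gives an at least 17-fold higher number from compound 2 to compound 4 (1.24 log units; beyond the scatter), and hydrogen in place of methoxy gives an at least 66-fold higher number from compound 1 to compound 4 (1.82 log units; beyond the scatter), so on this core a measurable number at the amide aryl position goes with the methoxy, the nitro or the ring nitrogen in these four compounds. The poor showing of compound 3 thus cannot be read as a penalty for the pyridin-3-yl ring nitrogen, since the all-carbon ring of compound 4 is the one that sits at the limit of the read-out.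

As far as these compounds go, all three new steps are bounds, so their true sizes remain open, as does the true position of compound 4 on this read-out. Also open, from the compounds shown here alone, is whether a methyl, a chlorine, an amine or a carboxylic acid on the phenyl would give a measurable number, and whether a methoxy on the pyridin-3-yl would add to the effect of the ring nitrogen.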